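Cyano for fluoro on the ether side chain, compound 2 to compound 3

The source may report more compounds than this note shows. Statements on the series, on what has been measured and on what is new or still open speak of the compounds shown alone.

In a functional assay on U-251 cells (Homo sapiens) for antiproliferative activity, read by MTT assay, with a stated time of 24 h (a higher number here means a weaker inhibitor, a lower number a stronger inhibitor), compound 1 `COc1cc(OC)c(-c2coc3cc(OCc4ccccc4)ccc3c2=O)cc1OC` gives 6750 nM and compound 2 `COc1cc(OC)c(-c2coc3cc(OCc4ccccc4F)ccc3c2=O)cc1OC` gives 2890 nM, the lower of the two numbers. Compound 3 `COc1cc(OC)c(-c2coc3cc(OCc4ccc(C#N)cc4)ccc3c2=O)cc1OC`, still unmeasured, differs from compound 2 by 4-cyanophenyl in place of 2-fluorophenyl on a saturated chain carbon bound to an oxygen on an aromatic ring, on the same side chain. Going by the values given here, the only measured step at this group is a 2.3-fold lower number from compound 1 to compound 2 (0.37 log units; beyond the scatter), a modest one. Among the compounds with values here, no measured compound carries a nitrile, so the direction remains open. The expected step is small, a 1.2-fold higher number from compound 2 to compound 3 (0.08 log units; within the scatter), probably not beyond the scatter. For compound 3 the estimated value is 3500 nM, with an expected range of 1300 nM to 9000 nM.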

Compound 3, half-maximal inhibitory concentration: 6180 nM
Compound 3: the middle estimate sits 1.8-fold (0.25 log units) below what was measured; measured number inside the range.
By their numbers in this assay, from the lowest: compound 2; then compounds 3 and 1 (each within the scatter of the next).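

In this assay, the side chain does not reward every ring substituent: a 2.1-fold higher number from compound 2 to compound 3 (0.33 log units; beyond the scatter), so the result for 2-fluorobenzyl does not extend to 4-cyanobenzyl. Set against the plain benzyl of compound 1, the nitrile gives a 1.1-fold lower number from compound 1 to compound 3 (0.04 log units; within the scatter), so adding a substituent does not by itself lower the number. Nothing available accounts for the difference between these two groups.

The compounds shown change the substituent and its place on the ring together, leaving those two effects unseparated. As far as these compounds go, how an amine or a carboxylic acid on this ring would read also remains open.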